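The source may report more compounds than this note shows. Statements on the series, on what has been measured and on what is new or still open speak of the compounds shown alone.

Compound 1 `Cc1ccsc1CN[C@@H]1C[C@H]2C[C@@H]([C@H]1C)C2(C)C` is the parent of a small set of three analogues whose values in an ADME assay on MDCK cells (Canis lupus familiaris) for cytotoxicity, read by microscopy, with a stated time of 48 h (on this read-out higher numbers stand for lower toxicity in this test and lower numbers for higher toxicity in this test), are known. Compound 1 gives 10000 nM, the highest number of the three. Compound 2 `Cc1ccc(CN[C@@H]2C[C@H]3C[C@@H]([C@H]2C)C3(C)C)s1` gives 780 nM, and compound 3 `C[C@H]1[C@H](NCc2cc(Br)cs2)C[C@H]2C[C@@H]1C2(C)C` gives 6250 nM. The step of a 13-fold lower number from compound 1 to compound 2 (1.11 log units; beyond the scatter) is the only large movement among them; the step of a 1.6-fold lower number from compound 1 to compound 3 (0.20 log units; within the scatter) stays within the scatter, while the step of an 8.0-fold higher number from compound 2 to compound 3 (0.90 log units; beyond the scatter) is modest.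

Compound 4 `C[C@H]1[C@H](NCc2sccc2-c2ccccc2)C[C@H]2C[C@@H]1C2(C)C` has not yet been measured in this assay. It differs from compound 1 by phenyl in place of methyl on an aromatic carbon. For the measured compounds named here, no measured pair exchanges a methyl for a phenyl; the three known steps all change a substituent on the same five-membered aromatic ring, and they range from no change beyond the scatter to a large fall in the number. Two of those three comparisons moved the number downward from compound 1, so a downward step is expected for compound 4 as well, though not a large one, given that the step of a 1.6-fold lower number from compound 1 to compound 3 (0.20 log units; within the scatter) shows a ring substituent can leave the number essentially unchanged. Compound 4 is therefore expected to give 5000 nM, between 1500 nM and 15000 nM, which would mean a step of a 2.0-fold lower number from compound 1 to compound 4 (0.30 log units; within the scatter).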

Compound 4, minimum cytotoxic concentration: 12500 nM
Estimate against measurement, compound 4: 2.5-fold (0.40 log units) below, within the range that was stated.
By their numbers in this assay, from the lowest: compound 2; then compounds 3, 1 and 4 (each within the scatter of the next).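

In this assay phenyl in place of methyl on this aromatic carbon, next to the ring atom that bears a large group and two ring bonds from the ring sulfur, brings a 1.3-fold higher number from compound 1 to compound 4 (0.10 log units; within the scatter) and so leaves the number where it stood. The earlier compounds shown here showed only that 5-methylthiophen-2-yl in place of 3-methylthiophen-2-yl gives a 13-fold lower number from compound 1 to compound 2 (1.11 log units; beyond the scatter) and that 4-bromothiophen-2-yl in its place gives a 1.6-fold lower number from compound 1 to compound 3 (0.20 log units; within the scatter) and compound 4 adds that, at this carbon, a group of 6 heavy atoms can stand where 1 heavy atom stood without a step beyond the scatter. Nothing measured here accounts for this result.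

From the compounds shown here alone, it remains open whether the number also holds at this carbon with groups of another kind, such as a methoxy group, an amine or a carboxylic acid, or with a phenyl that itself carries a substituent. Going by these compounds, it is equally open whether a phenyl in the place of the methyl of 5-methylthiophen-2-yl would go with a low number like that of compound 2 or a high one like that of compound 4.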